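Swapping the Amide Aryl Group: Expected Clearance

The source may report more compounds than this note shows. Statements on the series, on what has been measured and on what is new or still open speak of the compounds shown alone.

Among the measured compounds shown here, in an ADME assay on microsomes from liver (Rattus norvegicus) for metabolic stability, read by LC-MS, using NADPH, with stated times of 10 min and 30 min (a lower number here means slower removal, a higher number faster removal of the compound), compound 2 `Cn1cc(C(=O)N2CC(Oc3cncc(N4C(=O)c5ccc(Cl)cc5C4(C)C)c3)C2)cn1` gives 6.4 mL/min/kg, the top of the two numbers so far, though only within the scatter of compound 1 `CCS(=O)(=O)N1CC(Oc2cncc(N3C(=O)c4ccc(Cl)cc4C3(C)C)c2)C1`, which gives 5 mL/min/kg. Compound 3 `Cc1ccncc1C(=O)N1CC(Oc2cncc(N3C(=O)c4ccc(Cl)cc4C3(C)C)c2)C1` differs from compound 2 at the carbonyl carbon: 4-methylpyridin-3-yl in place of 1-methyl-1H-pyrazol-4-yl on a carbonyl carbon. For the measured compounds named here, the one measured step, a 1.3-fold higher number from compound 1 to compound 2 (0.11 log units; within the scatter), also altered the group on the ring nitrogen and moved little. A similarly small shift is therefore expected, a 1.3-fold higher number from compound 2 to compound 3 (0.10 log units; within the scatter), in no clear direction beyond the scatter. Compound 3 is estimated at 8 mL/min/kg, between 4 mL/min/kg and 16 mL/min/kg.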

Compound 3, clearance in the Rattus norvegicus assay: 10.4 mL/min/kg
For compound 3 the middle estimate is 1.3-fold (0.11 log units) below the measured one; measured number inside the range.
By their numbers in the Rattus norvegicus assay, from the lowest: compounds 1, 2 and 3 (each within the scatter of the next, the first and the last beyond it).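

Among the compounds shown here, in the Rattus norvegicus assay, the change on the carbonyl carbon alone stays small, a 1.6-fold higher number from compound 2 to compound 3 (0.21 log units; within the scatter), but the (4-methylpyridin-3-yl)carbonyl group in place of ethylsulfonyl gives the only step so far beyond the scatter, a 2.1-fold higher number from compound 1 to compound 3 (0.32 log units; beyond the scatter). In a physicochemical assay for solubility, in phosphate buffer, with a stated time of 2 h, at pH 6.5 (on this read-out higher numbers stand for higher solubility and lower numbers for lower solubility), compound 2 gives 310 ug/mL and compound 3 gives 290 ug/mL, two values within the scatter of each other. Nothing available explains these numbers. From the compounds shown here alone, how a phenyl group or an unsubstituted pyridin-3-yl group on that carbonyl carbon would read in these two assays remains open.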